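Methoxy in Place of Chloro on a Chalcone Acetamide

The source may hold more compounds than are shown below. What is called first, only, known or untested is meant among the compounds shown, and "the series" means these compounds.

Measured so far:
Compound 1 `Nc1ccc(C(=O)/C=C/c2ccc(Cl)cc2)cc1`: 60%
Compound 2 `COc1ccc(/C=C/C(=O)c2ccc(NC(=O)CBr)cc2)cc1`: 46%
Compound 3 `O=C(CO[N+](=O)[O-])Nc1ccc(C(=O)/C=C/c2ccc(Cl)cc2)cc1`: 69%

In a functional assay on the whole organism (strain albino) for inhibition, with Rattus norvegicus as the target, read by paw edema, with stated times of 30 min and 3 h, at a dose of 100 mg/kg by the oral route (a higher number here means more inhibition at the dose given (going by the name of the read-out), a lower number less inhibition), compound 3 gives the highest of the three numbers, though its gap to compound 1 lies within the scatter a number 9 percentage points higher from compound 1 to compound 3 (within the scatter); only compound 2 sits clearly lower. Compound 4 `COc1ccc(/C=C/C(=O)c2ccc(NC(=O)CO[N+](=O)[O-])cc2)cc1` differs from compound 3 by methoxy in place of chloro on an aromatic carbon. Within the data shown here, no measured step follows this exact change. Among the measured compounds shown here, compound 2, the only other compound carrying methoxy, differs from compound 3 in a second place too, so its lower value gives only a loose hint. A modest downward step is therefore expected, a number 14 percentage points lower from compound 3 to compound 4 (beyond the scatter), with wide uncertainty. Compound 4 is estimated at 55%, between 35% and 75%.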

Compound 4, a percentage reported as inhibition, in the whole organism at one dose (the size of the read-out at that dose, not a potency): 53%
Compound 4: the middle estimate sits 2 percentage points above what was measured; the range from low to high includes it.
By their numbers in this assay, from the lowest: compounds 2, 4, 1 and 3 (each within the scatter of the next, the first and the last beyond it).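

In this assay, among these compounds, the change from 4-chlorophenyl to 4-methoxyphenyl gives a number 16 percentage points lower from compound 3 to compound 4 (beyond the scatter), so this position does respond to a change of group, which the earlier compounds could only hint at. With methoxy held in place, nitrooxy in place of bromo gives a number 7 percentage points higher from compound 2 to compound 4 (within the scatter), so that swap shows no clear effect on this core. Nothing measured here explains either step. The compounds shown leave open how a fluoro, hydroxy or dimethylamino group would read at this position. They also leave open whether methoxy lowers the number on the core of compound 1.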